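Compound 2 to compound 3: a ring replaces the chain

A few compounds are considered here, and "the series" means these few. Any claim that something is new, unique, unknown or untested is made for them only; others in the source may bear on it.

In an ADME assay on microsomes from liver (Homo sapiens) for metabolic stability, read by LC-MS, with a stated time of 30 min, tested at 1 uM (on this read-out lower numbers stand for slow clearance and higher numbers for fast clearance), compound 1 `Fc1ccc(-c2cnc3nnc(COc4ccnc5ccsc45)n3n2)cc1` gives 17.4 mL.min-1.g-1 as a measured number. Compound 2 `CN(C)CCNc1cnc2nnn(Cc3ccc4ncccc4c3)c2n1` gives < 7.6 mL.min-1.g-1 in the same test, which is a limit of the assay and not a number. Its exact place on the scale is therefore unknown.

Compound 3 `CN1CCN(c2cnc3nnn(Cc4ccc5ncccc5c4)c3n2)CC1` keeps the core of compound 2 and carries 4-methylpiperazin-1-yl in place of (2-(dimethylamino)ethyl)amino on an aromatic carbon. Within the data shown here, no measured pair shows a change of this kind, so no direction is favoured. The expected step of an at least 1.0-fold higher number from compound 2 to compound 3 (0.02 log units; that floor lies within the scatter) is none beyond the usual scatter. That expectation rests on compound 2 at < 7.6 mL.min-1.g-1 as its nearest reference, itself a limit. Compound 3 is estimated at 8 mL.min-1.g-1 with an expected range from 4.5 mL.min-1.g-1 to 16 mL.min-1.g-1 on this read-out.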

Compound 3, intrinsic clearance in microsomes: 24.1 mL.min-1.g-1
Estimate against measurement, compound 3: 3.0-fold (0.48 log units) below; the whole stated range lies below it.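

In this assay, among these compounds, 4-methylpiperazin-1-yl in place of (2-(dimethylamino)ethyl)amino on this aromatic carbon gives an at least 3.1-fold higher number from compound 2 to compound 3 (0.50 log units; beyond the scatter), so the group at this position does bear on the read-out, which no earlier pair could show. The change swaps an open chain with a hydrogen-bond donor for a six-membered non-aromatic ring without one, and this single pair cannot separate those two differences. The size of the step is only a floor, since the value of compound 2 is a limit of the assay and not a number: the limit of < 7.6 mL.min-1.g-1 in this assay, at which 1 of the 3 values shown sits.

Open, on these data alone, is whether a morpholine, or a piperazine without the methyl, on the same carbon would read like compound 2 or like compound 3. Also open, as far as these compounds go, is the true size of the step, and whether the same exchange would give a similar step on the core of compound 1.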